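This account rests on a few compounds, and the source may have more. Where it says the series, first, only, none or still open, it means among the compounds named here.

Series notes. Compound 1 `COc1nc(-c2cccc(Cl)c2)ccc1[C@@H](c1ccccc1)[C@@](O)(CCN(C)C)c1cccc2ccccc12` has no reported result in a toxicity assay on HeLa cells (Homo sapiens) for cytotoxicity (a higher number here means that more compound is tolerated, a lower number that less compound is tolerated), entered as "nd" (no result reported), so its standing there is open and can only be framed by its neighbours. Compound 2 `COc1nc(-c2cnsc2)ccc1[C@@H](c1ccccc1)[C@@](O)(CCN(C)C)c1cccc2ccccc12` gives 28.8 ug/mL in this assay. Compound 3 `COc1nc(C(C)(C)C)ccc1[C@@H](c1ccccc1)[C@@](O)(CCN(C)C)c1cccc2ccccc12` reaches only a limit of the assay, > 64 ug/mL, and not a number. Among the measured compounds shown here, the one measured step, an at least 2.2-fold higher number from compound 2 to compound 3 (0.34 log units; beyond the scatter), is the sole guide here, and it runs up to the limit of > 64 ug/mL in this assay, at which 1 of the 3 values shown sits. Compound 4 `COc1nc(C2CCCCC2)ccc1[C@@H](c1ccccc1)[C@@](O)(CCN(C)C)c1cccc2ccccc12` differs from compound 1 by cyclohexyl in place of 3-chlorophenyl on an aromatic carbon. That change also sets a non-aromatic ring of carbon only where an aromatic ring stood, so a number at or past the same limit is expected for compound 4, with no direction stated against compound 1, which has no value. Compound 4 is estimated at 60 ug/mL, between 30 ug/mL and 110 ug/mL.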

Compound 4, half-maximal cytotoxic concentration: 57.7 ug/mL
For compound 4 the middle estimate is 1.0-fold (0.02 log units) above the measured one, and the stated range covers the measured number.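

In this assay, cyclohexyl, a non-aromatic ring of carbon only, gives a number rather than a limit at this position next to the ring nitrogen, with an at least 1.1-fold lower number from compound 3 to compound 4 (0.04 log units; that floor lies within the scatter). The comparison with the aromatic 1,2-thiazol-4-yl group gives a 2.0-fold higher number from compound 2 to compound 4 (0.30 log units; within the scatter), so these compounds do not separate cyclohexyl from either group. Compound 3 alone remains a limit and not a number: the limit of > 64 ug/mL in this assay, at which 1 of the 4 values shown sits.

With no result for compound 1, the change from 3-chlorophenyl to cyclohexyl cannot be read. On these data alone, how an amine or a carboxylic acid at this position would behave in this assay remains open.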